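Halogenated phenoxy change, compound 2 to compound 3

The source may hold more compounds than are shown below. What is called first, only, known or untested is meant among the compounds shown, and "the series" means these compounds.

In a functional assay with Homo sapiens as the target (a higher number here means a weaker inhibitor, a lower number a stronger inhibitor), compound 1 (`CC(C)[C@H](NC(=O)COc1cccc2ccccc12)C(=O)N[C@@H](CC(=O)O)C(=O)COc1c(F)cc(F)cc1F`) gives 14900 nM, and compound 2 (`CC(C)[C@H](NC(=O)COc1cccc2ccccc12)C(=O)N[C@@H](CC(=O)O)C(=O)COc1c(F)c(F)c(F)c(F)c1F`) gives 8890 nM. Among the measured compounds shown here, these are the only two numbers so far, and compound 2 stands within the scatter of compound 1, so the pair cannot be ranked.

Compound 3 (`CC(C)[C@H](NC(=O)COc1cccc2ccccc12)C(=O)N[C@@H](CC(=O)O)C(=O)COc1c(Cl)cccc1Cl`) keeps the shared core and carries 2,6-dichlorophenyl in place of 2,3,4,5,6-pentafluorophenyl on an oxygen on a saturated carbon.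

For the measured compounds named here, one measured step bears on this change. It sits at the same place, a 1.7-fold lower number from compound 1 to compound 2 (0.22 log units; within the scatter), and stays within the scatter. Going by the values given here, it exchanges one fluorinated group for another, and no compound with chlorine on this group has been measured, so the support is indirect. On this single small step, no change beyond the scatter is expected in this assay, and neither direction is favoured.

The expected step is small, a 1.1-fold higher number from compound 2 to compound 3 (0.05 log units; within the scatter). The estimated value for compound 3 is 10000 nM, with an expected range of 4000 nM to 25000 nM.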

Compound 3, half-maximal inhibitory concentration: 15300 nM
Compound 3: the middle estimate sits 1.5-fold (0.18 log units) below what was measured; the range from low to high includes it.
By their numbers in this assay, from the lowest: compounds 2, 1 and 3 (each within the scatter of the next).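

Chlorine now stands on this group for the first time in the series, and the change to 2,6-dichlorophenyl on an oxygen on a saturated carbon gives a 1.7-fold higher number from compound 2 to compound 3 (0.24 log units; within the scatter) and a 1.0-fold higher number from compound 1 to compound 3 (0.01 log units; within the scatter) in this assay. Both steps lie within the scatter, so this position tolerates chlorine as well as fluorine, and the exchange of one halogen for the other, together with the different number of halogens on the ring, produces no readable change here. The three halogenated phenyl groups therefore cannot be ranked against one another, and no supporting measurement accompanies this result to say more about it.

All three groups shown at this place are halogenated phenyl rings, so it remains open whether a plain phenyl, or a phenyl carrying methoxy, an amine or a carboxylic acid, would stay level with them or move the number beyond the scatter. From the compounds shown here alone, it also remains open whether this place can shift the number in this assay at all, or whether the values are set by other parts of the shared core.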